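From 1H-pyrrol-2-yl to furan-2-yl on the carbonyl carbon

A few compounds are considered here, and "the series" means these few. Any claim that something is new, unique, unknown or untested is made for them only; others in the source may bear on it.

Of the compounds shown here, three sharing one core have been tested in a functional assay on MOLT-4 cells (Homo sapiens) for inhibition, read by MTT assay, with a stated time of 48 h; a lower number here means a stronger inhibitor, a higher number a weaker inhibitor. Compound 2 `O=C(/C=C/c1ccc(Cl)cc1)c1ccc[nH]1` gives 22000 nM, and compound 3 `O=C(/C=C/c1ccc(Br)cc1)c1ccc[nH]1` gives 49000 nM. Compound 1 `O=C(/C=C/c1ccccc1)c1ccc[nH]1` gives > 100000 nM; that figure is a limit of the assay rather than a number, as shown by the limit of > 100000 nM in this assay, at which 1 of the 3 values shown sits. Of the two numbers, compound 2 holds the lower one, and its nearest neighbour is compound 3, with a 2.2-fold higher number from compound 2 to compound 3 (0.35 log units; beyond the scatter). The other measured steps, an at least 4.5-fold lower number from compound 1 to compound 2 (0.65 log units; beyond the scatter) and an at least 2.0-fold lower number from compound 1 to compound 3 (0.30 log units; that floor lies within the scatter), likewise concern only the substituent on the aromatic carbon of the cinnamoyl-side ring.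

Compound 4 `O=C(/C=C/c1ccc(Cl)cc1)c1ccco1` has not yet been measured. It differs from compound 2 by furan-2-yl in place of 1H-pyrrol-2-yl on a carbonyl carbon. Within the data shown here, none of the measured steps touches the carbonyl carbon or the ring attached to it, so they offer no direct guide to this change; the chloro on the aromatic carbon is kept, and compound 2 is the closest measured reference. In this assay the expected step is a 1.1-fold higher number from compound 2 to compound 4 (0.06 log units; within the scatter), that is, no change beyond the scatter is foreseen. Compound 4 is therefore estimated at 25000 nM. The range for compound 4 is expected to run from 8000 nM to 90000 nM.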

Compound 4, half-maximal inhibitory concentration: 23000 nM
Compound 4: the middle estimate sits 1.1-fold (0.04 log units) above what was measured; low and high end bracket the measured number.
By their numbers in this assay, from the lowest: compounds 2 and 4 (each within the scatter of the next); then compound 3. At a limit, above all of these: compound 1.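

Among these compounds, the earlier compounds changed only the substituent on an aromatic carbon and left the ring on the carbonyl carbon untouched; this step is the first to alter that ring, and in this assay it reads a 1.0-fold higher number from compound 2 to compound 4 (0.02 log units; within the scatter). With the chloro kept, furan-2-yl and 1H-pyrrol-2-yl therefore cannot be told apart in this pair, even though the exchange removes the hydrogen-bond donor of 1H-pyrrol-2-yl and brings in the hydrogen-bond acceptor of furan-2-yl. Nothing among the data shown bears on why the two groups give such closely matching numbers.

The compounds shown leave open whether this match between the two rings would carry over from the chloro of compound 2 and compound 4 to the bromo of compound 3, or to the unsubstituted aromatic ring of compound 1. From the compounds shown here alone, it is likewise open whether a thiophen-2-yl ring or a plain phenyl ring on the carbonyl carbon would stay level with compound 2 and compound 4 or move away from them.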